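A few compounds are considered here, and "the series" means these few. Any claim that something is new, unique, unknown or untested is made for them only; others in the source may bear on it.

The series shares one core, seen in compound 1 `Cc1cccc(/C=N/Nc2ncc3c(n2)n(C2CCCC2)c(=O)c(=O)n3C)c1`, compound 2 `COc1cccc(/C=N/Nc2ncc3c(n2)n(C2CCCC2)c(=O)c(=O)n3C)c1` and compound 3 `Cn1c(=O)c(=O)n(C2CCCC2)c2nc(N/N=C/c3cccs3)ncc21`, and varies only in the aromatic group carried on the carbon that is double-bonded to nitrogen. In a functional assay on HCT-116 cells (Homo sapiens) for antiproliferative activity, read by MTT assay (on this read-out lower numbers stand for stronger inhibition and higher numbers for weaker inhibition), compound 1 reaches only the limit of the assay, > 100000 nM. Among the compounds with values here, that limit is the single such value here (the limit of > 100000 nM in this assay, at which 1 of the 3 values shown sits). Compound 2 gives 45800 nM in this assay, and compound 3 gives 52600 nM. Compound 3 thus holds the higher of the two numbers, yet its gap to compound 2, a 1.1-fold higher number from compound 2 to compound 3 (0.06 log units; within the scatter), is within the scatter, so the two cannot be ordered. The other step, an at least 1.9-fold lower number from compound 1 to compound 3 (0.27 log units; that floor lies within the scatter), has a floor that also lies within the scatter.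

Compound 4 `Cn1c(=O)c(=O)n(C2CCCC2)c2nc(N/N=C/c3ccccc3F)ncc21` has not yet been measured. It differs from compound 3 by 2-fluorophenyl in place of thiophen-2-yl on a carbon with a double bond to nitrogen. Both steps that bear on it, a 1.1-fold higher number from compound 2 to compound 3 (0.06 log units; within the scatter) and an at least 1.9-fold lower number from compound 1 to compound 3 (0.27 log units; that floor lies within the scatter), exchange one aromatic group for another at the same carbon, and neither shows a move beyond the scatter with certainty. The step from compound 3 to compound 4 is therefore expected to be of the same small kind, a 1.1-fold lower number from compound 3 to compound 4 (0.02 log units; within the scatter), in no set direction. Compound 4 is expected to give 50000 nM in this assay, within 20000 nM to 150000 nM.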

Compound 4, half-maximal inhibitory concentration: 20700 nM
Beside the measured number, compound 4's estimate is 2.4-fold (0.38 log units) above it; low and high end bracket the measured number.
By their numbers in this assay, from the lowest: compound 4; then compounds 2 and 3 (each within the scatter of the next). At a limit, above all of these: compound 1.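

Compound 2 and compound 3 could not be ordered, and neither gave a step between two exact numbers that moved beyond the scatter, but 2-fluorophenyl on the carbon with a double bond to nitrogen does give such steps: a 2.5-fold lower number from compound 3 to compound 4 (0.41 log units; beyond the scatter) and a 2.2-fold lower number from compound 2 to compound 4 (0.34 log units; beyond the scatter). With an at least 4.8-fold lower number from compound 1 to compound 4 (0.68 log units; beyond the scatter) as well, every step to compound 4 is printed as beyond the scatter, which makes compound 4 the strongest of the compounds shown in this assay and shows that the choice of aromatic group at this carbon can shift the number measurably. The value of compound 1 is a limit, so the last of these steps gives only a floor: the limit of > 100000 nM in this assay, at which 1 of the 4 values shown sits.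

The compounds shown leave open whether the lower number of compound 4 goes with the fluorine or with the six-membered aromatic ring of carbon only, a question that an unsubstituted phenyl would address. They also leave open how a chlorophenyl, a pyridine ring or a phenyl ring bearing an amine would read at this carbon.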